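The source may report more compounds than this note shows. Statements on the series, on what has been measured and on what is new or still open speak of the compounds shown alone.

The measured compounds and their values in an assay on isolated protein for agonist activity at Bile acid receptor (Homo sapiens), read by FRET; on this read-out lower numbers stand for an effect already at smaller amounts and higher numbers for an effect only at larger amounts of compound:

Compound 1, `O=C(O)c1cccc(OCc2ccc(OCc3c(-c4c(Cl)cccc4Cl)noc3C3CC3)nc2C(F)(F)F)c1`: 43 nM
Compound 2, `O=C(O)c1ccc(OCc2ccc(OCc3c(-c4c(Cl)cccc4Cl)noc3C3CC3)nc2C(F)(F)F)cc1`: 76 nM
Compound 3, `CC(Oc1cccc(C(=O)O)c1)c1ccc(OCc2c(-c3c(Cl)cccc3Cl)noc2C2CC2)nc1C(F)(F)F`: 155 nM

Compound 1 and compound 2 share one core and differ in a single change, (4-carboxyphenyl in place of 3-carboxyphenyl on an oxygen on a saturated carbon). The step that this change made was a 1.8-fold higher number from compound 1 to compound 2 (0.25 log units; within the scatter). Compound 3 and compound 4, `CC(Oc1ccc(C(=O)O)cc1)c1ccc(OCc2c(-c3c(Cl)cccc3Cl)noc2C2CC2)nc1C(F)(F)F`, differ from each other by the same change, (4-carboxyphenyl in place of 3-carboxyphenyl on an oxygen on a saturated carbon), and the place where it sits is described in the same words for both pairs, so it counts as the same change, occurring twice among these compounds. The two cores differ by methyl in place of hydrogen on a saturated chain carbon bound to an aromatic carbon and an oxygen on an aromatic ring, and that difference made the step of a 3.6-fold higher number from compound 1 to compound 3 (0.56 log units; beyond the scatter), while the step of a 2.0-fold higher number from compound 2 to compound 3 (0.31 log units; beyond the scatter) joins the two pairs.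

For compound 4 the step of a 1.6-fold higher number from compound 3 to compound 4 (0.21 log units; within the scatter) is expected to be of similar size to the earlier one, because a 1.8-fold higher number from compound 1 to compound 2 (0.25 log units; within the scatter) on the other core, with the warning that a step of that size sits inside the usual scatter and may not reappear. Compound 4 is therefore estimated at 250 nM in this assay, with a range from 110 nM to 560 nM.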

Compound 4, half-maximal effective concentration: 352 nM
Compound 4: the middle estimate sits 1.4-fold (0.15 log units) below what was measured, and the stated range covers the measured number.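

In this assay, 4-carboxyphenyl in place of 3-carboxyphenyl on the methyl-bearing core gives a 2.3-fold higher number from compound 3 to compound 4 (0.36 log units; beyond the scatter), and this agrees with what the same change did on the other core: the same change on two cores in this assay, a 1.8-fold higher number (0.25 log units; within the scatter) from compound 1 to compound 2 and a 2.3-fold higher number (0.36 log units; beyond the scatter) from compound 3 to compound 4, 1.3-fold (0.11 log units) apart, within the scatter of two such steps
Methyl in place of hydrogen on the saturated chain carbon also carries over from one carboxyphenyl group to the other, with a 4.6-fold higher number from compound 2 to compound 4 (0.67 log units; beyond the scatter) closely matching its earlier step: the same change on two cores in this assay, a 3.6-fold higher number (0.56 log units; beyond the scatter) from compound 1 to compound 3 and a 4.6-fold higher number (0.67 log units; beyond the scatter) from compound 2 to compound 4, 1.3-fold (0.11 log units) apart, within the scatter of two such steps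
With both changes together the gap grows to an 8.2-fold higher number from compound 1 to compound 4 (0.91 log units; beyond the scatter), so among these four compounds each change has a similar size on both cores, but each is seen on only two cores, which does not show that it would hold on any other core.

Going by these compounds, it remains open whether a larger group on that chain carbon, such as an ethyl, would continue the trend set by methyl. Also open, on these data alone, is how a primary amide or a tetrazole in place of the carboxylic acid would fare in this assay.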